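This account rests on a few compounds, and the source may have more. Where it says the series, first, only, none or still open, it means among the compounds named here.

Compound 3 `COc1ncc(Cl)cc1C(=O)NCCC1CCN(S(=O)(=O)NC(=O)NC[C@@H]2C[C@@H]3C=C[C@@H]2C3)CC1` gives 20% in a functional assay on the whole organism (blood) with Rattus norvegicus as the target, with stated times of 24 h and 1 h, at a dose of 1 mg/kg by the intraperitoneal route (a lower number here means a weaker effect, a higher number a stronger effect of the compound at the dose given), the second highest of three numbers. Compound 2 `O=C(NC[C@@H]1C[C@@H]2C=C[C@@H]1C2)NS(=O)(=O)N1CCC(CCNC(=O)c2cc(Cl)ccn2)CC1` gives 16%; the change between them is a number 4 percentage points higher from compound 2 to compound 3 (within the scatter). Within the data shown here, compound 1 `COc1ccc(Cl)cc1C(=O)NCCC1CCN(S(=O)(=O)NC(=O)NC2CCCCC2)CC1` gives 39%, a number beyond the scatter above compound 3, but it differs from compound 3 in more than the aromatic group, so no single step joins them. Compound 4 `O=C(NC[C@@H]1C[C@@H]2C=C[C@@H]1C2)NS(=O)(=O)N1CCC(CCNC(=O)c2nc3ccccc3s2)CC1` carries 1,3-benzothiazol-2-yl in place of 5-chloro-2-methoxypyridin-3-yl on a carbonyl carbon. Among the measured compounds shown here, the only measured step that bears on this change is a number 4 percentage points higher from compound 2 to compound 3 (within the scatter), which also exchanged the aromatic group on the carbonyl carbon and stayed within the scatter. On that basis compound 4 is expected to show no step beyond the scatter, namely a number 2 percentage points higher from compound 3 to compound 4 (within the scatter). Compound 4 is therefore estimated at 22%, with a range from 8% to 40%.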

Compound 4, a percentage reported as activity, at one dose (the size of the read-out at that dose, not a potency): 14%
The estimate for compound 4 lay 8 percentage points above the measured number; low and high end bracket the measured number.
By their numbers in this assay, from the lowest: compounds 4, 2 and 3 (each within the scatter of the next); then compound 1.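

On this carbonyl carbon, 1,3-benzothiazol-2-yl brings a five-membered aromatic ring together with a six-membered aromatic ring of carbon only, yet this assay records a number 6 percentage points lower from compound 3 to compound 4 (within the scatter) and a number 2 percentage points lower from compound 2 to compound 4 (within the scatter) as well. Three different aromatic groups at this place are therefore not told apart by this read-out at the dose given. No measurement shown bears on why this is so. On these data alone, it remains open whether an aromatic group carrying a carboxylic acid or an amine at this place would give a step beyond the scatter.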